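Cyclopropyloxy in Place of Cyclopropylmethyl: An Expectation

The source may hold more compounds than are shown below. What is called first, only, known or untested is meant among the compounds shown, and "the series" means these compounds.

Compound 1 `C=CCc1ccccc1OCC1=NCCN1`: 977 nM
Compound 2 `c1ccc(OCC2=NCCN2)c(CC2CC2)c1`: 1700 nM

In an assay on isolated protein for agonist activity at Alpha-2B adrenergic receptor (Homo sapiens) (a lower number here means that less compound is needed, a higher number that more compound is needed for the effect), compound 1 gives 977 nM and compound 2 gives 1700 nM. The step of a 1.7-fold higher number from compound 1 to compound 2 (0.24 log units; within the scatter) leaves compound 2 at the higher of the two numbers but not separated from compound 1. Compound 3 `c1ccc(OC2CC2)c(OCC2=NCCN2)c1` differs from compound 2 by cyclopropyloxy in place of cyclopropylmethyl on an aromatic carbon. Within the data shown here, no measured step bears directly on this change, since the only step in hand, a 1.7-fold higher number from compound 1 to compound 2 (0.24 log units; within the scatter), altered the saturated chain carbon and stayed within the scatter, so no movement beyond the scatter is expected here. Compound 3 is expected to give 2500 nM, between 800 nM and 8000 nM. The expected step is a 1.5-fold higher number from compound 2 to compound 3 (0.17 log units; within the scatter).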

Compound 3, half-maximal effective concentration: 3160 nM
Compound 3: the middle estimate sits 1.3-fold (0.10 log units) below what was measured; the range from low to high includes it.
By their numbers in this assay, from the lowest: compounds 1, 2 and 3 (each within the scatter of the next, the first and the last beyond it).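

In this assay, cyclopropyloxy in place of cyclopropylmethyl on this aromatic carbon adds an oxygen and a hydrogen-bond acceptor, yet the step is a 1.9-fold higher number from compound 2 to compound 3 (0.27 log units; within the scatter), so the two groups are not separated here. Against allyl, cyclopropyloxy gives the one step among these compounds that clears the scatter, though only modestly: a 3.2-fold higher number from compound 1 to compound 3 (0.51 log units; beyond the scatter). No measurement at hand explains either step. From the compounds shown here alone, whether an amine, a carboxylic acid or a longer chain on this aromatic carbon would give a number beyond the scatter of these three remains open.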